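Pyridin-2-yl in place of 4-(trifluoromethyl)phenyl: a cytotoxicity estimate

The source may hold more compounds than are shown below. What is called first, only, known or untested is meant among the compounds shown, and "the series" means these compounds.

Compound 3, `C=CCOc1cc(OC)c(C(=O)/C=C/c2ccc(C(F)(F)F)cc2)c(OCC=C)c1`: 7200 nM
Compound 1, `C=CCOc1cc(OC)c(C(=O)/C=C/c2ccco2)c(OCC=C)c1`: 191000 nM
Compound 2, `C=CCOc1cc(OC)c(C(=O)/C=C/c2ccc[nH]2)c(OCC=C)c1`: "not determined" (no result reported)

In an ADME assay on Vero cells (Chlorocebus sabaeus) for cytotoxicity, read by MTT assay (a lower number here means a stronger inhibitor, a higher number a weaker inhibitor), compound 3 gives 7200 nM, the lowest of the two numbers measured. Compound 1 lies far above it: a 27-fold lower number from compound 1 to compound 3 (1.42 log units; beyond the scatter). Compound 2 gave no result.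

Compound 4, `C=CCOc1cc(OC)c(C(=O)/C=C/c2ccccn2)c(OCC=C)c1`, is the next step. pyridin-2-yl in place of 4-(trifluoromethyl)phenyl on a double-bonded chain carbon bound to a double-bonded chain carbon

Going by the values given here, only one measured step bears on this change, and it runs the other way: a 27-fold lower number from compound 1 to compound 3 (1.42 log units; beyond the scatter) when 4-(trifluoromethyl)phenyl replaced furan-2-yl. Removing 4-(trifluoromethyl)phenyl again, for pyridin-2-yl, is therefore expected to raise the number in this assay by a large step, though the data cannot say whether as far as compound 1. The expected step is a 5.6-fold higher number from compound 3 to compound 4 (0.74 log units; beyond the scatter). Compound 4 is estimated at 40000 nM, within 12000 nM to 130000 nM.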

Compound 4, half-maximal inhibitory concentration: 2800 nM
For compound 4 the middle estimate is 14-fold (1.15 log units) above the measured one; measured number outside the range, below it.
By their numbers in this assay, from the lowest: compound 4; then compound 3; then compound 1.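

In this assay the choice of ring at this place on the double-bonded chain carbon matters even among ring groups of similar size, with a 68-fold lower number from compound 1 to compound 4 (1.83 log units; beyond the scatter) when pyridin-2-yl replaces furan-2-yl. There is also a 2.6-fold lower number from compound 3 to compound 4 (0.41 log units; beyond the scatter), so 4-(trifluoromethyl)phenyl is not needed for the lowest number of the three compounds. No available evidence explains this order. Still open, from the compounds shown here alone, is whether an amine or a carboxylic acid at this place would lower the number further or raise it.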